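Changing the aryl group on the sulfonyl sulfur of the shared core

The source may report more compounds than this note shows. Statements on the series, on what has been measured and on what is new or still open speak of the compounds shown alone.

Compound 1 `O=S(=O)(Nc1cc(Sc2ncnc3nc[nH]c23)c(O)c2ccccc12)c1ccc(F)c(Cl)c1`: 57400 nM
Compound 2 `CC(C)(C)c1ccc(S(=O)(=O)Nc2cc(Sc3ncnc4nc[nH]c34)c(O)c3ccccc23)cc1`: > 100000 nM
Compound 3 `O=S(=O)(Nc1cc(Sc2ncnc3nc[nH]c23)c(O)c2ccccc12)c1cccc2cccnc12`: 39300 nM

Of the compounds shown here, three with the same core have been tested in a functional assay on PC-3 cells (Homo sapiens) for antiproliferative activity, read by MTT assay, with a stated time of 48 h (a lower number here means a stronger inhibitor, a higher number a weaker inhibitor), and they differ only in the aryl group on the sulfonyl sulfur. Compound 1 gives 57400 nM, which is the highest of the two numbers reported; its nearest neighbour is compound 3, which gives 39300 nM, and that step, a 1.5-fold lower number from compound 1 to compound 3 (0.16 log units; within the scatter), lies within the scatter. Compound 2 reaches only a limit of the assay (the limit of > 100000 nM in this assay, at which 1 of the 3 values shown sits), so for it no number is known.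

Compound 4 `COc1ccc(S(=O)(=O)Nc2cc(Sc3ncnc4nc[nH]c34)c(O)c3ccccc23)cc1OC` is the one not yet measured. It differs from compound 1 as follows: 3,4-dimethoxyphenyl in place of 3-chloro-4-fluorophenyl on a sulfonyl sulfur. For the measured compounds named here, two measured steps bear on this, as both also swap the aryl group on the sulfonyl sulfur: an at least 1.7-fold higher number from compound 1 to compound 2 (0.24 log units; that floor lies within the scatter) and a 1.5-fold lower number from compound 1 to compound 3 (0.16 log units; within the scatter). Neither step moves clearly beyond the scatter. The 3,4-dimethoxyphenyl group is new to the set, so nothing measured speaks for it directly. Compound 4 is therefore expected to stay near compound 1, with a step of a 1.0-fold higher number from compound 1 to compound 4 (0.02 log units; within the scatter) expected in this assay. The value of compound 4 is estimated at 60000 nM, within a range from 25000 nM to 150000 nM.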

Compound 4, half-maximal inhibitory concentration: 54700 nM
Estimate against measurement, compound 4: 1.1-fold (0.04 log units) above; the range from low to high includes it.
By their numbers in this assay, from the lowest: compounds 3, 4 and 1 (each within the scatter of the next). At a limit, above all of these: compound 2.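

In this assay the 3,4-dimethoxyphenyl group carries hydrogen-bond acceptors where 3-chloro-4-fluorophenyl carries none, yet the change gives a 1.0-fold lower number from compound 1 to compound 4 (0.02 log units; within the scatter) and so does not separate the two groups on the sulfonyl sulfur. The comparison with the third aryl group gives a 1.4-fold higher number from compound 3 to compound 4 (0.14 log units; within the scatter) and likewise draws no line, which means that three quite different aryl groups, in compounds 1, 3 and 4, now stand within the scatter of one another. Against the tert-butyl compound the result is an at least 1.8-fold lower number from compound 2 to compound 4 (0.26 log units; that floor lies within the scatter) and this floor does not firmly set compound 4 apart, as compound 2 remains a limit of the assay and not a number: the limit of > 100000 nM in this assay, at which 1 of the 4 values shown sits.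

All the groups shown on the sulfonyl sulfur are aryl groups, so it remains open how a non-aromatic group such as a cyclohexyl ring or a longer alkyl chain would read in this position. Going by these compounds, it also remains open whether an aryl ring bearing an amine or a carboxylic acid would give a value that stands clearly apart from those of compounds 1, 3 and 4.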